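A methylindolyl group in place of fluorophenyl

A few compounds are considered here, and "the series" means these few. Any claim that something is new, unique, unknown or untested is made for them only; others in the source may bear on it.

Measured compounds:
compound 1 `O=C(/C=C\Nc1ccc(F)cc1)c1nc(-c2ccc(F)cc2)n2ccccc12` — 16900 nM
compound 2 `O=C(/C=C\Nc1ccc(F)cc1)c1nc(-c2ccc(C(F)(F)F)cc2)n2ccccc12` — > 30000 nM, a limit
compound 3 `O=C(/C=C\Nc1cnc2ccccc2c1)c1nc(-c2ccc(C(F)(F)F)cc2)n2ccccc12` — > 30000 nM, a limit

For the measured compounds named here, in a functional assay on BT-474 cells (Homo sapiens) for cytotoxicity, read by MTT assay, with a stated time of 48 h (on this read-out higher numbers stand for weaker inhibition and lower numbers for stronger inhibition), compound 1 gives 16900 nM, the only plain number among the three. Compound 2 reaches only the limit > 30000 nM. Compound 3 likewise reaches only the limit > 30000 nM. The step of an at least 1.7-fold higher number from compound 1 to compound 2 (0.24 log units; that floor lies within the scatter) alters a different part of the shared core. The step that the two limits leave unreadable from compound 2 to compound 3 changes the group on the amine nitrogen, the same place as here, but both ends sit at the limit (the limit of > 30000 nM in this assay, at which 2 of the 3 values shown sit), so its size cannot be read. Compound 4 `Cc1cc2cc(N/C=C\C(=O)c3nc(-c4ccc(F)cc4)n4ccccc34)ccc2[nH]1` differs from compound 1 by 2-methyl-1H-indol-5-yl in place of 4-fluorophenyl on an amine nitrogen. With no readable step at this place, no change beyond the scatter is expected; compound 4 is estimated at 12000 nM (range 3500 nM to 30000 nM), meaning an expected step of a 1.4-fold lower number from compound 1 to compound 4 (0.15 log units; within the scatter).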

Compound 4, half-maximal inhibitory concentration: > 30000 nM
Compound 4 gave a limit, no number; the forecaster's own chance of this, stated with the estimate: 30%; middle value at least 2.5-fold (0.39 log units) from the limit.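

For the compounds shown here, the only earlier change on the amine nitrogen could not be read, since both of its ends were limits, but starting from compound 1, which has a plain number, gives a step with a floor: in this assay, 2-methyl-1H-indol-5-yl in place of 4-fluorophenyl gives an at least 1.7-fold higher number from compound 1 to compound 4 (0.24 log units; that floor lies within the scatter). The result for compound 4 is a limit, so the larger two-ring group shows no gain in potency, and the readings now crowd at one end of the scale: the limit of > 30000 nM in this assay, at which 3 of the 4 values shown sit.

Still open, on these data alone, is whether a morpholine or a carboxylic acid on the amine nitrogen would give a lower number than compound 1.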